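The compounds below may be only part of what the source reports. "The series", "measured", "known", "first", "only" and "open" are said of these compounds alone.

Three compounds sharing one core have been tested in a functional assay on the whole organism (strain Wistar) for inhibition, with Rattus norvegicus as the target, read by paw edema, with stated times of 30 min and 1 h, at a dose of 20 mg/kg; a higher number here means more inhibition at the dose given (going by the name of the read-out), a lower number less inhibition:

Compound 1, `CCOC(=O)C1=C(C)NC(C)=C(C(=O)OCC)C1c1ccc(OCC(=O)NCc2ccccc2)cc1`: 16.1%
Compound 2, `CCOC(=O)C1=C(C)NC(C)=C(C(=O)OCC)C1c1ccc(OCC(=O)Nc2ccc(C)cc2)cc1`: 55.1%
Compound 3, `CCOC(=O)C1=C(C)NC(C)=C(C(=O)OCC)C1c1ccc(OCC(=O)Nc2nc3ccccc3s2)cc1`: 54.5%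

Compound 1 stands lowest of the three; compound 3 is nearest to it and compound 2 furthest, both beyond the scatter. Compound 4, `CCOC(=O)C1=C(C)NC(C)=C(C(=O)OCC)C1c1ccc(OCC(=O)NNC(=O)c2cccs2)cc1`, has not yet been measured. It differs from compound 1 at the amide-type nitrogen: ((thiophen-2-yl)carbonyl)amino in place of benzyl on an amide-type nitrogen. Among the compounds with values here, no measured step makes this exact exchange. The two steps that start from compound 1 both replace the benzyl on that nitrogen: a number 39 percentage points higher from compound 1 to compound 2 (beyond the scatter) and a number 38.4 percentage points higher from compound 1 to compound 3 (beyond the scatter). Between those two new groups the difference is small: a number 0.6 percentage points lower from compound 2 to compound 3 (within the scatter). The group entering in compound 4 resembles neither of them, as it carries a five-membered aromatic ring with 1 hetero atom, 1 hydrogen-bond donor and 2 hydrogen-bond acceptors. An increase is nevertheless expected because a number 39 percentage points higher from compound 1 to compound 2 (beyond the scatter) and a number 38.4 percentage points higher from compound 1 to compound 3 (beyond the scatter) both went up by a large amount on leaving the benzyl, though a smaller and less certain one is estimated here: a number 21.9 percentage points higher from compound 1 to compound 4 (beyond the scatter). Compound 4 is expected to give 38% in this assay, within a range from 18% to 58%.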

Compound 4, a percentage reported as inhibition, in the whole organism at one dose (the size of the read-out at that dose, not a potency): 55.1%
Beside the measured number, compound 4's estimate is 17.1 percentage points below it; measured number inside the range.
By their numbers in this assay, from the lowest: compound 1; then compounds 3, 2 and 4 (each within the scatter of the next).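

In this assay, putting ((thiophen-2-yl)carbonyl)amino in place of benzyl on the amide-type nitrogen gives a number 39 percentage points higher from compound 1 to compound 4 (beyond the scatter), so a third replacement now produces a large rise. This group shares little with the other two replacements, yet the readings show a number 0.6 percentage points higher from compound 3 to compound 4 (within the scatter) and no change at the digits printed from compound 2 to compound 4 (within the scatter), which leaves compounds 2, 3 and 4 level with one another. The rise is therefore not confined to 4-methylphenyl or 1,3-benzothiazol-2-yl, and among these four compounds benzyl is the only group that gives a low reading.

Nothing shown here explains why benzyl stands apart from the other three groups. Also open, on these data alone, is whether a small methyl group or a longer chain such as 2-phenylethyl on this nitrogen would stay low like benzyl or match the other three, and whether compounds 2, 3 and 4 would remain level at other doses, since a reading at one dose is not a measure of potency.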